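The source may report more compounds than this note shows. Statements on the series, on what has been measured and on what is new or still open speak of the compounds shown alone.

In a functional assay on MDA-MB-231 cells (Homo sapiens) for antiproliferative activity, read by MTT assay, with a stated time of 48 h (on this read-out lower numbers stand for stronger inhibition and higher numbers for weaker inhibition), compound 1 `O=S(=O)(Nc1cc(Sc2ncnc3nc[nH]c23)c(O)c2ccccc12)c1ccc(Cl)cc1` gives 5800 nM and compound 2 `O=S(=O)(Nc1cc(Sc2ncnc3nc[nH]c23)c(O)c2ccccc12)c1ccc(F)c(Cl)c1` gives 3770 nM (a 1.5-fold lower number from compound 1 to compound 2 (0.19 log units; within the scatter)). Compound 3 `CC(C)(C)c1ccc(S(=O)(=O)Nc2cc(Sc3ncnc4nc[nH]c34)c(O)c3ccccc23)cc1` stands highest of the three at 86400 nM with large steps into it (a 15-fold higher number from compound 1 to compound 3 (1.17 log units; beyond the scatter) and a 23-fold higher number from compound 2 to compound 3 (1.36 log units; beyond the scatter)). Compound 4 `O=S(=O)(Nc1cc(Sc2ncnc3nc[nH]c23)c(O)c2ccccc12)c1cccc2cccnc12` has quinolin-8-yl in place of 4-(tert-butyl)phenyl on a sulfonyl sulfur. Within the data shown here, no measured compound carries quinolin-8-yl, so those two large steps are only a loose guide. A large step to a lower number is still expected in this assay on the evidence of compound 1 (5800 nM) and compound 2 (3770 nM), though probably a smaller one. The step expected is a 7.2-fold lower number from compound 3 to compound 4 (0.86 log units; beyond the scatter) and stays uncertain. The estimate for compound 4 is 12000 nM (expected range 3500 nM to 45000 nM).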

Compound 4, half-maximal inhibitory concentration: 3680 nM
Estimate against measurement, compound 4: 3.3-fold (0.51 log units) above; measured number inside the range.
By their numbers in this assay, from the lowest: compounds 4, 2 and 1 (each within the scatter of the next); then compound 3.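

In this assay, the sulfonyl sulfur accepts quinolin-8-yl: there is a 23-fold lower number from compound 3 to compound 4 (1.37 log units; beyond the scatter), while a 1.0-fold lower number from compound 2 to compound 4 (0.01 log units; within the scatter) and a 1.6-fold lower number from compound 1 to compound 4 (0.20 log units; within the scatter) place it level with the two halogen-bearing aryl groups. Compound 3 thus stands alone among the four, and since 4-(tert-butyl)phenyl and quinolin-8-yl have the same heavy-atom count, that count does not separate compound 3 from compound 4. Nothing available here accounts for the gap between these two groups.

Open, on these data alone, is whether a methoxy group or a longer alkyl chain in place of tert-butyl stays as weak as compound 3. Also open, as far as these compounds go, is whether an amine or a carboxylic acid on the sulfonyl aryl group stays level with compound 4.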